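This account rests on a few compounds, and the source may have more. Where it says the series, first, only, none or still open, it means among the compounds named here.

Working notes on the series. Among the compounds with values here, in a functional assay on the whole organism with Rattus norvegicus as the target (on this read-out lower numbers stand for an effect already at smaller amounts and higher numbers for an effect only at larger amounts of compound), compound 2 `CC/N=C(\S)NCCCn1nc(-c2ccccc2)ccc1=O` gives 88.2 mg/kg, the only number in the set so far. Compound 1 `O=c1ccc(-c2ccccc2)nn1CCCCNC(=S)Nc1ccccc1` sits at a limit of this assay, > 100 mg/kg, which is the limit of > 100 mg/kg in this assay, at which 1 of the 2 values shown sits. On the numbers shown compound 2 thus stands alone, and the two values cannot be ordered. Compound 3 `CC/N=C(\S)NCCCCn1nc(-c2ccccc2)ccc1=O` has not been measured. It differs from compound 2 by a group of 7 heavy atoms (4 carbon, 2 nitrogen, 1 sulfur; no ring) in place of a group of 6 heavy atoms (3 carbon, 2 nitrogen, 1 sulfur; no ring), on a saturated chain carbon, three bonds along the chain from an aromatic nitrogen. Within the data shown here, no step between measured compounds is at hand to scale this change, so in this assay nothing beyond the scatter is expected from compound 2 to compound 3, with a fair chance that only a limit is returned. Compound 3 is expected at 100 mg/kg, within 45 mg/kg to 220 mg/kg, which corresponds to an expected step of a 1.1-fold higher number from compound 2 to compound 3 (0.05 log units; within the scatter).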

Compound 3, dose for half-maximal effect: 19.8 mg/kg
For compound 3 the middle estimate is 5.1-fold (0.70 log units) above the measured one, and the stated range ends above it.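

In this assay the change on a saturated chain carbon, three bonds along the chain from an aromatic nitrogen, can now be sized: a group of 7 heavy atoms in place of a group of 6 heavy atoms gives a 4.5-fold lower number from compound 2 to compound 3 (0.65 log units; beyond the scatter). On the amine nitrogen, a group with no ring in place of a group with a six-membered aromatic ring gives an at least 5.0-fold lower number from compound 1 to compound 3 (0.70 log units; beyond the scatter). That second step starts from compound 1, whose entry is a limit and not a number: the limit of > 100 mg/kg in this assay, at which 1 of the 3 values shown sits.

The compounds shown do not tell whether a longer chain would extend the first step or reverse it. Nor do they show how an amine or a carboxylic acid at the chain end would read out in this assay.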